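Replacing thiophen-3-yl on the shared core: the next step

The source may hold more compounds than are shown below. What is called first, only, known or untested is meant among the compounds shown, and "the series" means these compounds.

compound 1 `COc1ccc(-c2cn3ccnc3c(-c3ccc4ncn(C5CCCCC5)c4c3)n2)cc1` — 61.5%
compound 2 `c1cn2cc(-c3ccsc3)nc(-c3ccc4ncn(C5CCCCC5)c4c3)c2n1` — 23.1%

In a functional assay on UO-31 cells (Homo sapiens) for inhibition, read by sulforhodamine B assay, with a stated time of 48 h, tested at 10 uM (a lower number here means less inhibition, a higher number more inhibition at the concentration tested (going by the name of the read-out)), compound 1 gives 61.5%, while compound 2 gives 23.1%. Compound 2 therefore stands lowest of the two numbers, with compound 1 as its nearest neighbour and the higher one. Among the compounds with values here, the single measured step, a number 38.4 percentage points lower from compound 1 to compound 2 (beyond the scatter), came with thiophen-3-yl in place of 4-methoxyphenyl on an aromatic carbon. Compound 3 `COc1ccccc1-c1cn2ccnc2c(-c2ccc3ncn(C4CCCCC4)c3c2)n1` goes back the other way: 2-methoxyphenyl in place of thiophen-3-yl on an aromatic carbon. The step from compound 1 to compound 2 bears directly on this, as it exchanged a methoxyphenyl for the same thiophen-3-yl; here the methoxy sits on another carbon of the phenyl, so only part of that size is taken over. An upward step in this assay is expected, a number 21.9 percentage points higher from compound 2 to compound 3 (beyond the scatter), with wide uncertainty. Compound 3 is estimated at 45%, range 20% to 70%.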

Compound 3, a percentage reported as inhibition, at one concentration (the size of the read-out at that concentration, not a potency): 24%
The estimate for compound 3 lay 21 percentage points above the measured number; the range from low to high includes it.
By their numbers in this assay, from the lowest: compounds 2 and 3 (each within the scatter of the next); then compound 1.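

In this assay, 2-methoxyphenyl in place of thiophen-3-yl gives a number 0.9 percentage points higher from compound 2 to compound 3 (within the scatter) and so leaves the number where compound 2 stood: a methoxyphenyl at this aromatic carbon does not by itself carry the number of compound 1. Moving the methoxy on the phenyl gives a number 37.5 percentage points lower from compound 1 to compound 3 (beyond the scatter) and this separates the place of the methoxy from the change of ring, which the earlier pair could not do, so in this pair the 4-methoxyphenyl and the 2-methoxyphenyl are not interchangeable. No supporting data are available to explain this difference.

Open, going by these compounds, is how 3-methoxyphenyl would read at this carbon, and whether the methoxy of compound 1 matters as such. A plain phenyl, 4-hydroxyphenyl or 4-aminophenyl on the shared core would bear on that.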